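The compounds below may be only part of what the source reports. "The series", "measured", "known", "first", "only" and "open" are said of these compounds alone.

Of the compounds shown here, three of a shared core have been measured so far. Compound 1 `Cc1cc(OC(=O)c2ccc(CC(CO[N+](=O)[O-])O[N+](=O)[O-])cc2)n(-c2ccccc2)n1` gives 4.88 in a physicochemical assay for lipophilicity, read by HPLC, measured as octanol-water partition, at pH 7; a lower number here means a more polar compound, a higher number a more lipophilic compound. Compound 2 `Cc1cc(OC(=O)C(C)(C)CO[N+](=O)[O-])n(-c2ccccc2)n1` gives 3.55 in this assay, and compound 3 `Cc1cc(OC(=O)CCCCCO[N+](=O)[O-])n(-c2ccccc2)n1` gives 3.79. Among these three numbers compound 1 stands highest: the nearest of the others is compound 3, lower by an amount beyond the scatter, and the furthest is compound 2, lower by an amount also beyond the scatter. Among the compounds with values here, none of the three pairs differs in only one place, so no single step between measured compounds can be read off.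

Compound 4 `Cc1cc(OC(=O)c2ccc(CCCO[N+](=O)[O-])cc2)n(-c2ccccc2)n1` is the new member. It differs from compound 1 by hydrogen in place of nitrooxy on a saturated chain carbon bound to two saturated chain carbons, which amounts to a hydrogen in place of nitrooxy on a saturated chain carbon bound to two saturated chain carbons; cut one bond further out, the change reads 1,2-bis(nitrooxy)ethyl to 2-(nitrooxy)ethyl. Within the data shown here, no measured pair shows what such a change does in this assay, so the direction can only be guessed from the size of what leaves. A modest downward step, just beyond the scatter, seems the likeliest outcome; the step of a number 0.43 log units lower from compound 1 to compound 4 (beyond the scatter) is therefore expected. Compound 4 is estimated at 4.45, with a range from 3.95 to 4.95.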

Compound 4, partition coefficient: 4.76
Compound 4: the middle estimate sits 0.31 log units below what was measured; the range from low to high includes it.
By their numbers in this assay, from the lowest: compounds 2 and 3 (each within the scatter of the next); then compounds 4 and 1 (each within the scatter of the next).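

Within the data shown here, the pair gives the first reading of a single change. With hydrogen in place of nitrooxy on a saturated chain carbon bound to two saturated chain carbons, this assay shows a number 0.12 log units lower from compound 1 to compound 4 (within the scatter), so at this position the change from 1,2-bis(nitrooxy)ethyl to 2-(nitrooxy)ethyl leaves compound 1 and compound 4 indistinguishable in this read-out, even though a whole nitrooxy group leaves. Nothing available explains this outcome.

The compounds shown leave open whether this holds only for the exchange of nitrooxy for hydrogen, or also when a hydroxyl, an amine or a carboxylic acid stands on the same saturated chain carbon. They also leave open whether a longer chain carrying the remaining nitrooxy would stay within the scatter of compound 4, and whether the same exchange would read alike on a chain without the aromatic ester of compound 1 and compound 4, such as the chains of compound 2 and compound 3.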